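Moving the thiazole attachment point: compound 3 to compound 4

This account rests on a few compounds, and the source may have more. Where it says the series, first, only, none or still open, it means among the compounds named here.

The series varies the aromatic ring on a saturated chain carbon bound to an oxygen on a saturated carbon, the rest of the molecule being shared. Compound 1 `O=C(COCc1cccnc1)N1CCN(c2ccc(Cl)cc2Cl)CC1` gives 1090 nM in a functional assay on HEK293 cells for positive allosteric modulation of metabotropic glutamate receptor 5 (Homo sapiens), read by FLIPR and calcium flux; on this read-out higher numbers stand for an effect only at larger amounts of compound and lower numbers for an effect already at smaller amounts. Compound 2 `O=C(COCc1ccncn1)N1CCN(c2ccc(Cl)cc2Cl)CC1` gives 2800 nM in this assay, and compound 3 `O=C(COCc1cncs1)N1CCN(c2ccc(Cl)cc2Cl)CC1` gives 1280 nM in this assay. Compound 3 thus stands second highest of the three numbers, close to compound 1 and further from compound 2: the step of a 1.2-fold higher number from compound 1 to compound 3 (0.07 log units; within the scatter) lies within the scatter, while a 2.2-fold lower number from compound 2 to compound 3 (0.34 log units; beyond the scatter) and a 2.6-fold higher number from compound 1 to compound 2 (0.41 log units; beyond the scatter) are modest but beyond it.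

Compound 4 `O=C(COCc1nccs1)N1CCN(c2ccc(Cl)cc2Cl)CC1` differs from compound 3 in one place: 1,3-thiazol-2-yl in place of 1,3-thiazol-5-yl on a saturated chain carbon bound to an oxygen on a saturated carbon. For the measured compounds named here, no measured step swaps the attachment point of one and the same ring; each of the three steps seen exchanges one ring for another. The pyridin-3-yl to 1,3-thiazol-5-yl exchange, a 1.2-fold higher number from compound 1 to compound 3 (0.07 log units; within the scatter), shows that the ring can be replaced without a change beyond the scatter, whereas the pyrimidin-4-yl ring of compound 2 sits at the higher end. Keeping the thiazole and moving only its point of attachment is taken as a smaller change than either, so in this assay a step within the scatter is expected, with the range leaning slightly toward a higher number. The expected value for compound 4 is 1500 nM, between 600 nM and 4000 nM, a step of a 1.2-fold higher number from compound 3 to compound 4 (0.07 log units; within the scatter).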

Compound 4, half-maximal effective concentration: 10300 nM
The estimate for compound 4 lay 6.9-fold (0.84 log units) below the measured number; the measured number lies above the stated range.
By their numbers in this assay, from the lowest: compounds 1 and 3 (each within the scatter of the next); then compound 2; then compound 4.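

Within the series, the point of attachment at this position carries more weight than the exchange of one ring for another in this assay: the two thiazole isomers have the same atoms and the same printed counts, yet they are separated by the largest step seen so far among compounds 1 to 4 (an 8.0-fold higher number from compound 3 to compound 4 (0.91 log units; beyond the scatter)). The 1,3-thiazol-2-yl ring also places compound 4 beyond the scatter of both other rings (a 3.7-fold higher number from compound 2 to compound 4 (0.57 log units; beyond the scatter); a 9.4-fold higher number from compound 1 to compound 4 (0.98 log units; beyond the scatter)), so compound 4 has the highest number of the four, while the 1,3-thiazol-5-yl ring of compound 3 remains within the scatter of the pyridin-3-yl ring of compound 1, and thiazole as such does not fix the result. No supporting measurement accompanies these values, so the origin of the attachment effect remains unexplained.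

Open, on these data alone, is whether a similar dependence on attachment point appears with 1,3-thiazol-4-yl, or with pyridin-2-yl and pyridin-4-yl in the pyridine case. Also open, as far as these compounds go, is whether 1,3-oxazol-2-yl on the same saturated chain carbon would follow compound 4 or compound 3.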